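The compounds below may be only part of what the source reports. "The series", "measured", "known", "first", "only" and "open" are said of these compounds alone.

Measured compounds:
compound 1 `COc1ccc2c(c1)OC(COc1ccc(CCC(=O)O)c(F)c1)CC2`, a functional assay on HEK293 cells for agonist activity at Free fatty acid receptor 1 (Homo sapiens), read by fluorescence and calcium flux, with a stated time of 10 min (on this read-out higher numbers stand for an effect only at larger amounts of compound and lower numbers for an effect already at smaller amounts), 2110 nM
compound 2 `CS(=O)(=O)CCCOc1ccc2c(c1)OC(COc1ccc(CCC(=O)O)c(F)c1)CC2`, 36300 nM
compound 3 `CCOC(CC(=O)O)c1ccc(OCC2COc3ccc(Cl)cc3O2)cc1`, 640 nM

Compound 3 gives the lowest number of the three; compound 1 stands nearest to it, and compound 2 furthest away. Within the data shown here, the one step measured between two compounds differing in a single place, a 17-fold higher number from compound 1 to compound 2 (1.24 log units; beyond the scatter), concerns a chain added at an oxygen on an aromatic ring, not the part of the molecule that changes here.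

Compound 4 `O=C(O)CC(c1ccncc1)c1ccc(OCC2COc3ccc(Cl)cc3O2)cc1` differs from compound 3 by pyridin-4-yl in place of ethoxy on a saturated chain carbon bound to an aromatic carbon and a saturated chain carbon. Among the measured compounds shown here, no measured step touches this saturated chain carbon, so nothing among the three compounds says how the number in this assay should move, in either direction. The account therefore expects for compound 4 a number close to that of compound 3, with the step of a 1.3-fold lower number from compound 3 to compound 4 (0.11 log units; within the scatter) taken as the estimated change. Compound 4 is expected to give about 500 nM, within a range from 100 nM to 3000 nM.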

Compound 4, half-maximal effective concentration: 1170 nM
Compound 4: the middle estimate sits 2.3-fold (0.37 log units) below what was measured, within the range that was stated.
By their numbers in this assay, from the lowest: compounds 3, 4 and 1 (each within the scatter of the next, the first and the last beyond it); then compound 2.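

In this assay, the first step measured at this saturated chain carbon, bound to an aromatic carbon and a saturated chain carbon, is a 1.8-fold higher number from compound 3 to compound 4 (0.26 log units; within the scatter) and stays within the scatter. Among these compounds, the position therefore accepts pyridin-4-yl, with 6 heavy atoms and a six-membered aromatic ring, in place of ethoxy, with 3 heavy atoms and no ring, without a change beyond the scatter, unlike the large step seen at the other site in the earlier compounds. Nothing available explains this result.

As far as these compounds go, whether a phenyl ring, an amine or a longer chain such as butoxy would be tolerated equally at this carbon remains open. So does whether pyridin-4-yl would behave the same way on a different core.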